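Swapping a Saturated Ring for an Aromatic One on a Second Core

A few compounds are considered here, and "the series" means these few. Any claim that something is new, unique, unknown or untested is made for them only; others in the source may bear on it.

Compound 1 `COc1ccnc(NC[C@@H]2C[C@@H](OCC(=O)NC[C@H](NC(=O)C3(C)CCCCC3)C(=O)O)CN2C(=O)OCc2ccccc2)c1`: 0.8 nM
Compound 2 `COc1ccnc(NC[C@@H]2C[C@@H](OCC(=O)NC[C@H](NC(=O)c3c(C)cc(C)cc3C)C(=O)O)CN2C(=O)OCc2ccccc2)c1`: 0.54 nM
Compound 3 `CC(C)(C)CC(=O)N1C[C@H](OCC(=O)NC[C@H](NC(=O)C2(C)CCCCC2)C(=O)O)C[C@H]1CNc1ccccn1`: 1.4 nM

All three numbers come from an assay on a protein complex for inhibition of integrin alpha-5/beta-1 (Homo sapiens), read by ELISA; a lower number here means a stronger inhibitor, a higher number a weaker inhibitor. Compound 1 and compound 2 share one core and differ by 2,4,6-trimethylphenyl in place of 1-methylcyclohexyl on a carbonyl carbon; that change gave a 1.5-fold lower number from compound 1 to compound 2 (0.17 log units; within the scatter). Compound 3 sits on a second core; how this core differs from that of compound 1 is not broken down here. Compound 4 `Cc1cc(C)c(C(=O)N[C@@H](CNC(=O)CO[C@@H]2C[C@@H](CNc3ccccn3)N(C(=O)CC(C)(C)C)C2)C(=O)O)c(C)c1` is the unmeasured partner of compound 3, carrying (2,4,6-trimethylphenyl in place of 1-methylcyclohexyl on a carbonyl carbon), the same change as between compound 1 and compound 2, at a place described in the same words. Given the small step seen from compound 1 to compound 2, compound 4 is expected to move from compound 3 by a 1.6-fold lower number from compound 3 to compound 4 (0.19 log units; within the scatter) in this assay. The estimate for compound 4 is therefore 0.9 nM, with a likely range from 0.4 nM to 2 nM.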

Compound 4, half-maximal inhibitory concentration: 1.6 nM
The estimate for compound 4 lay 1.8-fold (0.25 log units) below the measured number, and the stated range covers the measured number.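

On the core of compound 3, the change from 1-methylcyclohexyl to 2,4,6-trimethylphenyl gave a 1.1-fold higher number from compound 3 to compound 4 (0.06 log units; within the scatter) in this assay. Set beside the first core, the change gives steps that do not differ on the two cores: the same change on two cores in this assay, a 1.5-fold lower number (0.17 log units; within the scatter) from compound 1 to compound 2 and a 1.1-fold higher number (0.06 log units; within the scatter) from compound 3 to compound 4, 1.7-fold (0.23 log units) apart, within the scatter of two such steps. This shows that, in this assay, the two groups can stand in for each other on both cores, but it does not show that either group is the better one, since both steps are too small to give a direction, nor that this would hold on a third core.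

The compounds shown leave open how a plain phenyl, without the three methyl groups, would compare. They also leave open what a ring containing nitrogen or a chain bearing an amine would do on this carbonyl carbon.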